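The source may report more compounds than this note shows. Statements on the series, on what has been measured and on what is new or still open speak of the compounds shown alone.

Compound 1 `COc1ccc(CSc2nc(Cc3ccccc3Br)c(C)c(=O)[nH]2)cc1` gives 179000 nM in an ADME assay on MT4 cells (Homo sapiens) for cytotoxicity, read by MTT assay; on this read-out lower numbers stand for higher toxicity in this test and higher numbers for lower toxicity in this test.
Compound 2 `Cc1c(Cc2ccccc2Br)nc(SCc2ccc([N+](=O)[O-])cc2)[nH]c1=O` gives only a limit of this assay, >= 246000 nM.
Compound 3 `CCc1c(Cc2cccc(Br)c2)nc(SCc2ccc(OC)cc2)[nH]c1=O` gives 201000 nM in this assay.

Two pairs are built on the same change, nitro in place of methoxy on an aromatic carbon. Between compound 1 and compound 2 it reads (nitro in place of methoxy on an aromatic carbon). The step it made was an at least 1.3-fold higher number from compound 1 to compound 2 (0.13 log units; that floor lies within the scatter); the reading of compound 2 sits at the limit of >= 246000 nM in this assay, at which 1 of the 3 values shown sits, so the true size of that step is not known. The same change between compound 3 and compound 4 `CCc1c(Cc2cccc(Br)c2)nc(SCc2ccc([N+](=O)[O-])cc2)[nH]c1=O` reads (nitro in place of methoxy on an aromatic carbon), and the place given for both is the same word for word. How the core of compound 3 differs from the core of compound 1 is not broken down here. Compound 3 and compound 1 give numbers that lie within the scatter of each other, so no order is read between them.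

For compound 4 in this assay the step is expected to be a 1.3-fold higher number from compound 3 to compound 4 (0.11 log units; within the scatter), because the same change gave an at least 1.3-fold higher number from compound 1 to compound 2 (0.13 log units; that floor lies within the scatter) and the reading of compound 2 sits at the limit of >= 246000 nM in this assay, at which 1 of the 3 values shown sits, so a limit rather than a number is quite possible. The estimate for compound 4 is 260000 nM, with a range from 150000 nM to 450000 nM.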

Compound 4, half-maximal cytotoxic concentration: 187000 nM
Compound 4: the middle estimate sits 1.4-fold (0.14 log units) above what was measured; the measured number falls inside the stated range.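

On the core of compound 3, the change from 4-methoxyphenyl to 4-nitrophenyl in this assay gave a 1.1-fold lower number from compound 3 to compound 4 (0.03 log units; within the scatter), so the two compounds of this pair cannot be put in any order. Set beside the same change on the core of compound 1, the two steps compare as follows: the same change on two cores in this assay, an at least 1.3-fold higher number (0.13 log units; that floor lies within the scatter) from compound 1 to compound 2 and a 1.1-fold lower number (0.03 log units; within the scatter) from compound 3 to compound 4; the limit leaves it open whether they differ

Compound 2 stands only at a limit of the assay, >= 246000 nM, so the pair on the core of compound 1 has no closed step, and what carries over from that core to the core of compound 3 is only this: neither pair shows a step beyond the scatter, while an equal effect on both cores is not shown.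

The compounds shown hold only methoxy and nitro at this place, on a six-membered aromatic ring of carbon only, para to a large group, so it stays open how an amine or a carboxylic acid there would read in this assay. It also stays open whether the change would behave alike on further cores, since the two cores here differ in more than one place and those differences are not taken apart by the pairs shown.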